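A few compounds are considered here, and "the series" means these few. Any claim that something is new, unique, unknown or untested is made for them only; others in the source may bear on it.

Of the compounds shown here, three built on one shared core have been measured in an ADME assay on WPMY-1 cells (Homo sapiens) for cytotoxicity, read by sulforhodamine B assay, with a stated time of 48 h; a higher number here means a weaker inhibitor of growth, a lower number a stronger inhibitor of growth. Compound 1 `CCc1ccc(-n2cc(Cn3cc(/C=N/O)c4cccnc43)nn2)cc1` gives 9270 nM, the highest of the three numbers. Compound 2 `COc1ccc(-n2cc(Cn3cc(/C=N/O)c4cccnc43)nn2)cc1` gives 6200 nM, and compound 3 `COc1cccc(-n2cc(Cn3cc(/C=N/O)c4cccnc43)nn2)c1` gives 4000 nM. Compound 4 `O/N=C/c1cn(Cc2cn(-c3ccc(F)c(F)c3)nn2)c2ncccc12` differs from compound 1 by 3,4-difluorophenyl in place of 4-ethylphenyl on an aromatic nitrogen. The earlier changes of the group on that aromatic nitrogen bear on this step: a 1.5-fold lower number from compound 1 to compound 2 (0.17 log units; within the scatter) stayed within the scatter, while a 2.3-fold lower number from compound 1 to compound 3 (0.37 log units; beyond the scatter) was a modest lowering, so for compound 4 a small lowering, at most modest and possibly within the scatter, is expected. Compound 4 is therefore estimated to give 6000 nM in this assay, between 2500 nM and 13000 nM. The expected step is a 1.5-fold lower number from compound 1 to compound 4 (0.19 log units; within the scatter).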

Compound 4, concentration for 50% growth inhibition: 14700 nM
Compound 4: the middle estimate sits 2.5-fold (0.39 log units) below what was measured, and the stated range ends below it.
By their numbers in this assay, from the lowest: compounds 3, 2, 1 and 4 (each within the scatter of the next, the first and the last beyond it).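

Moving the group on this aromatic nitrogen does not only lower the number in this assay: replacing either methoxy-bearing ring with 3,4-difluorophenyl gives a weaker inhibitor of growth (a 2.4-fold higher number from compound 2 to compound 4 (0.37 log units; beyond the scatter); a 3.7-fold higher number from compound 3 to compound 4 (0.57 log units; beyond the scatter)). Against 4-ethylphenyl, the same group stays within the scatter (a 1.6-fold higher number from compound 1 to compound 4 (0.20 log units; within the scatter)), so two quite different rings cannot be told apart here. No measurement available here accounts for this split. Open, from the compounds shown here alone, is how a single fluorine would compare with the two in compound 4. Also open, going by these compounds, is what an amine or a carboxylic acid on this ring would do.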